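This account rests on a few compounds, and the source may have more. Where it says the series, first, only, none or still open, it means among the compounds named here.

Compound 1 `CC(=O)Nc1ccc(S(=O)(=O)NNc2ccc(F)c(Br)c2)cc1`, compound 2 `CC(=O)Nc1ccc(S(=O)(=O)NNc2ccc(F)c(Cl)c2)cc1` and compound 3 `CC(=O)Nc1ccc(S(=O)(=O)NNc2ccc(Br)c(F)c2)cc1` share one core and differ only in the groups carried on one of the aromatic rings. In an assay on HeLa cells for inhibition of Indoleamine 2,3-dioxygenase 1 (Homo sapiens), read by spectrophotometry, with a stated time of 24 h (a lower number here means that less compound is needed, a higher number that more compound is needed for the effect), compound 1 gives 2490 nM, and compound 2 gives 2590 nM. For the measured compounds named here, the single change between them is chloro in place of bromo on an aromatic carbon, and it made a step of a 1.0-fold higher number from compound 1 to compound 2 (0.02 log units; within the scatter). Compound 3 has the same atoms as compound 1, joined differently; the difference between the two cores is not broken down here. In this assay compound 3 gives 187 nM, the lowest of the three numbers, and its gap to compound 1 and to compound 2 lies beyond the scatter in both cases.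

Compound 4 `CC(=O)Nc1ccc(S(=O)(=O)NNc2ccc(Cl)c(F)c2)cc1` has not yet been measured. It differs from compound 3 by chloro in place of bromo on an aromatic carbon. Going by the values given here, this is the same kind of change as the one between compound 1 and compound 2: in both, the exchanged atom sits on an aromatic carbon of a six-membered aromatic ring of carbon only, ortho to a fluoro group, but in compound 2 it is meta to a large group, whereas in compound 4 it is para to a large group. Set beside the earlier step of a 1.0-fold higher number from compound 1 to compound 2 (0.02 log units; within the scatter), the step from compound 3 to compound 4 is expected to be a 1.1-fold higher number from compound 3 to compound 4 (0.05 log units; within the scatter), because in compound 2 this exchange gave 2590 nM against the value of compound 1. Compound 4 is therefore estimated to give 210 nM, with the likely range running from 90 nM to 480 nM.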

Compound 4, half-maximal effective concentration: 84 nM
Compound 4: the middle estimate sits 2.5-fold (0.40 log units) above what was measured; measured number below the stated range.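

In this assay, chloro in place of bromo gave a 2.2-fold lower number from compound 3 to compound 4 (0.35 log units; beyond the scatter), a modest step. Set beside the same exchange on the core of compound 1, this step cannot be told apart from the earlier one, so the data give no firm sign that the choice of core alters what the exchange does: the same change on two cores in this assay, a 1.0-fold higher number (0.02 log units; within the scatter) from compound 1 to compound 2 and a 2.2-fold lower number (0.35 log units; beyond the scatter) from compound 3 to compound 4, 2.3-fold (0.36 log units) apart, within the scatter of two such steps This does not show that the exchange carries over unchanged either, since one step lies within the scatter and the other beyond it, and two pairs of compounds are too few to set a rule for any other core in this series.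

The compounds shown leave open what other groups would do at this place on the ring, such as iodo, a methyl group or a nitrile, since only bromo and chloro appear there. Also open, going by these compounds, is whether the step from bromo to chloro would look the same on a core that carries a methoxy group or a hydrogen where these compounds carry the fluoro group.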